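The source may hold more compounds than are shown below. What is called first, only, known or untested is meant among the compounds shown, and "the series" means these compounds.

Compound 2 `O=c1cc(C2CCCCC2)oc2ccc(OCCCCCCN3CCCCC3)cc12` gives 55 nM in an assay on isolated protein (Cavia porcellus) with Sigma non-opioid intracellular receptor 1 (Homo sapiens) as the target, read by radioligand binding; on this read-out higher numbers stand for weaker inhibition and lower numbers for stronger inhibition; compound 1 `O=c1cc(C2CCC2)oc2ccc(OCCCCCCN3CCCCC3)cc12` gives 51 nM in this assay, and the two numbers sit within the scatter of each other, as the step of a 1.1-fold higher number from compound 1 to compound 2 (0.03 log units; within the scatter) shows. Compound 3 `O=c1cc(-c2cccnc2)oc2ccc(OCCCCCCN3CCCCC3)cc12` follows from compound 2 by pyridin-3-yl in place of cyclohexyl on an aromatic carbon. Among the compounds with values here, the one measured step on the same aromatic carbon, cyclohexyl for cyclobutyl, was flat; no measured step exchanges a non-aromatic ring for an aromatic one with a nitrogen, so the expectation rests on that flat step alone, with wide bounds. A modest weakening is expected for compound 3, as the step of a 2.2-fold higher number from compound 2 to compound 3 (0.34 log units; beyond the scatter). Compound 3 is estimated at 120 nM, expected between 40 nM and 400 nM.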

Compound 3, half-maximal inhibitory concentration: 119 nM
Estimate against measurement, compound 3: 1.0-fold (0.00 log units) above; the range from low to high includes it.
By their numbers in this assay, from the lowest: compounds 1 and 2 (each within the scatter of the next); then compound 3.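

In this assay pyridin-3-yl at this carbon next to the ring oxygen gives a 2.2-fold higher number from compound 2 to compound 3 (0.34 log units; beyond the scatter) and a 2.3-fold higher number from compound 1 to compound 3 (0.37 log units; beyond the scatter), so this position does respond to the ring placed on it. Within the data shown here, the earlier exchange between the two non-aromatic rings showed no such step, and the shift here is modest. Nothing available here accounts for the shift.

The compounds shown cannot separate the ring nitrogen from aromaticity itself. A phenyl group on this carbon, or pyridin-2-yl or pyridin-4-yl, would bear on that question.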